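Compound 4: the same atoms as compound 2, stereocentres undrawn

The source may report more compounds than this note shows. Statements on the series, on what has been measured and on what is new or still open speak of the compounds shown alone.

Of the compounds shown here, three share a core and have been measured in an assay on isolated protein for agonist activity at Bile acid receptor (Homo sapiens), read by FRET; on this read-out lower numbers stand for an effect already at smaller amounts and higher numbers for an effect only at larger amounts of compound. Compound 1 `CCO[C@]1(c2ccc(OCc3c(-c4c(Cl)cccc4Cl)noc3C3CC3)cc2Cl)C[C@H](c2cccc(C(=O)O)c2)C1` gives 277 nM, compound 3 `O=C(O)c1cccc([C@H]2C[C@@H](c3ccc(OCc4c(-c5c(Cl)cccc5Cl)noc4C4CC4)cc3Cl)C2)c1` gives 77 nM, and compound 2 `CS(=O)(=O)NC(=O)c1ccc([C@@H]2C[C@H]2c2ccc(OCc3c(-c4c(Cl)cccc4Cl)noc3C3CC3)cc2Cl)cc1` gives 48 nM. Compound 2 has the lowest number of the three; compound 3 lies within the scatter of it, while compound 1 lies beyond it. For the measured compounds named here, the one single-change step seen so far, a 3.6-fold lower number from compound 1 to compound 3 (0.56 log units; beyond the scatter), concerns a different part of the core and does not bear on the step now followed.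

Compound 4 `CS(=O)(=O)NC(=O)c1ccc(C2CC2c2ccc(OCc3c(-c4c(Cl)cccc4Cl)noc3C3CC3)cc2Cl)cc1` differs from compound 2 as follows: the two compounds have the same atoms and bonds; at least one stereo element is drawn with a configuration in one of them and without one in the other: 2 of 2 stereo elements differ; a stereocentre at a saturated ring carbon is drawn R in compound 2 and without a configuration in compound 4; a stereocentre at a saturated ring carbon is drawn R in compound 2 and without a configuration in compound 4. Going by the values given here, no measured pair here shows what drawing the two ring stereocentres without configuration does to the number in this assay. Compound 4 could therefore match compound 2 or give a somewhat higher number; a step of about a 1.6-fold higher number from compound 2 to compound 4 (0.19 log units; within the scatter) is expected, not clearly beyond the scatter. Compound 4 is thus estimated at 75 nM, with a range from 35 nM to 200 nM.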

Compound 4, half-maximal effective concentration: 90 nM
For compound 4 the middle estimate is 1.2-fold (0.08 log units) below the measured one, and the stated range covers the measured number.
By their numbers in this assay, from the lowest: compounds 2, 3 and 4 (each within the scatter of the next); then compound 1.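

In this assay, the two stereocentres at saturated ring carbons come into question for the first time among the compounds shown, and the result is a 1.9-fold higher number from compound 2 to compound 4 (0.27 log units; within the scatter). This pair therefore gives no clear sign that drawing a configuration at these two carbons changes the number, a point that the step involving the ethoxy group could not address. The whole comparison rests on one difference in how the two structures are written: the fact that one of compounds 2 and 4 is drawn with a defined configuration and the other without, at the place where they differ

On these data alone, it remains open whether compound 4 is a single stereoisomer or a mixture, and what number the opposite configuration at these two ring carbons would give. Also open, as far as these compounds go, is how the number would respond to an amine or a longer chain in place of the methyl on the sulfonyl group.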